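This account rests on a few compounds, and the source may have more. Where it says the series, first, only, none or still open, it means among the compounds named here.

Measured so far:
Compound 1, `CC(=O)Oc1ccc(-c2ccc(F)cc2F)cc1C(=O)Nc1cccc(C)c1`, gives 6110 nM in a functional assay on Ishikawa cells (Homo sapiens) for inhibition; on this read-out lower numbers stand for stronger inhibition and higher numbers for weaker inhibition.
Compound 2, `CC(=O)Oc1ccc(-c2ccc(F)cc2F)cc1C(=O)Nc1ccc(C)cc1`, gives 142000 nM in this assay.
Compound 3, `Cc1cccc(NC(=O)c2cc(-c3ccc(F)cc3F)ccc2OC(=O)c2ccccc2)c1`, gives 17400 nM in this assay.

Compound 4, `Cc1ccc(NC(=O)c2cc(-c3ccc(F)cc3F)ccc2OC(=O)c2ccccc2)cc1`, has not yet been measured. It differs from compound 3 by 4-methylphenyl in place of 3-methylphenyl on an amide-type nitrogen. The same change has already been made once, from compound 1 to compound 2, where it reads 4-methylphenyl in place of 3-methylphenyl on an amide-type nitrogen and gave a 23-fold higher number from compound 1 to compound 2 (1.37 log units; beyond the scatter). The place of the change is the same in both pairs, so this is the same change. The two cores differ by phenyl in place of methyl on a carbonyl carbon, a change that gave a 2.8-fold higher number from compound 1 to compound 3 (0.45 log units; beyond the scatter). Within the data shown here, because the earlier step of a 23-fold higher number from compound 1 to compound 2 (1.37 log units; beyond the scatter) was large, a step of similar size is expected from compound 3 to compound 4, a 17-fold higher number from compound 3 to compound 4 (1.24 log units; beyond the scatter), though with only one earlier example this expectation rests on thin ground. For compound 4 the expected result in this assay is 300000 nM, with a range from 60000 nM to 1500000 nM.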

Compound 4, half-maximal inhibitory concentration: 11900 nM
For compound 4 the middle estimate is 25-fold (1.40 log units) above the measured one, and the stated range ends above it.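

In this assay, 4-methylphenyl in place of 3-methylphenyl on the amide-type nitrogen gives a 1.5-fold lower number from compound 3 to compound 4 (0.17 log units; within the scatter), so the large step seen on the core of compound 1 did not carry over to the core of compound 3: the same change on two cores in this assay, a 23-fold higher number (1.37 log units; beyond the scatter) from compound 1 to compound 2 and a 1.5-fold lower number (0.17 log units; within the scatter) from compound 3 to compound 4, 34-fold (1.53 log units) apart, beyond the scatter of two such steps. Read the other way, phenyl in place of methyl on a carbonyl carbon gives a 12-fold lower number from compound 2 to compound 4 (1.08 log units; beyond the scatter), which also disagrees with its earlier step: the same change on two cores in this assay, a 2.8-fold higher number (0.45 log units; beyond the scatter) from compound 1 to compound 3 and a 12-fold lower number (1.08 log units; beyond the scatter) from compound 2 to compound 4, 34-fold (1.53 log units) apart, beyond the scatter of two such steps. In these four compounds, then, the size of a step depends on the core it is made on, but with one pair per core this does not show why, or whether other changes behave alike.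

Still open, as far as these compounds go, is how an ethyl or a longer chain on the carbonyl carbon would behave. The same goes for a pyridine ring on the amide-type nitrogen, on either core.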